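Chloro for methoxy on the benzyl arm of a dithiocarbamate

This account rests on a few compounds, and the source may have more. Where it says the series, first, only, none or still open, it means among the compounds named here.

Of the compounds shown here, two with a shared core have been tested in a functional assay on MCF7 cells (Homo sapiens) for inhibition, read by MTT assay, with a stated time of 72 h; a lower number here means a stronger inhibitor, a higher number a weaker inhibitor. Compound 1 `O=C(OCc1ccccc1)N1CCN(C(=S)SCc2cn(Cc3ccc(Cl)cc3)nn2)CC1` gives 27500 nM. Compound 2 `COc1ccc(Cn2cc(CSC(=S)N3CCN(C(=O)OC(C)(C)C)CC3)nn2)cc1` gives 4960 nM, the lowest of the two numbers; the gap to compound 1 lies beyond the scatter, and the two compounds differ in more than one place, so the numbers alone cannot be traced to either difference.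

The next compound, compound 3 `CC(C)(C)OC(=O)N1CCN(C(=S)SCc2cn(Cc3ccc(Cl)cc3)nn2)CC1`, is reached from compound 2 by one change: chloro in place of methoxy on an aromatic carbon. Compound 3 carries the same carbamate as compound 2 and the same benzyl group as compound 1, so it stands between the two measured compounds in structure. Among the measured compounds shown here, no single-change step is available that would show what chloro in place of methoxy does on this core. For the measured compounds named here, the expectation is therefore a small shift, if any, toward a higher number, leaning on compound 1 with its 27500 nM as the only compound bearing the chloro group. For compound 3 the estimated step is a 1.8-fold higher number from compound 2 to compound 3 (0.26 log units; within the scatter). Compound 3 is expected to give about 9000 nM, within a range from 3000 nM to 30000 nM.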

Compound 3, half-maximal inhibitory concentration: 2960 nM
Compound 3: middle estimate off by 3.0-fold (0.48 log units), on the high side; measured number below the stated range.
By their numbers in this assay, from the lowest: compounds 3 and 2 (each within the scatter of the next); then compound 1.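

Exchanging 4-methoxybenzyl for 4-chlorobenzyl with the tert-butyl carbamate held fixed gives a 1.7-fold lower number from compound 2 to compound 3 (0.22 log units; within the scatter) in this assay, so on this core the measurement does not separate the two groups. This single change also shows that the chloro group does not by itself bring a number as high as that of compound 1. Among the compounds shown here, with the 4-chlorobenzyl arm held fixed, tert-butyl in place of benzyl on the carbamate oxygen gives a 9.3-fold lower number from compound 1 to compound 3 (0.97 log units; beyond the scatter), the only single-change step here that lies beyond the scatter, and it ties the higher number in this pair to the benzyl carbamate of compound 1. Nothing measured at hand accounts for either step.

Going by these compounds, whether chloro and methoxy also remain inseparable alongside a benzyl carbamate stays open, as does whether the large step seen on the carbamate holds with the 4-methoxybenzyl arm. Also open, on these data alone, is how an amine or a carboxylic acid on the aromatic ring, or a longer chain on the carbamate oxygen, would read in this assay.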